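The compounds below may be only part of what the source reports. "The series", "measured", "known", "first", "only" and "open" are said of these compounds alone.

Compound 2 `CC(C)(CO)[C@@H](O)C(=O)N/C=C\C(=O)OCc1ccccc1` and compound 1 `CCOC(=O)/C=C\NC(=O)[C@H](O)C(C)(C)CO` share a core and differ only in the ester group. In an ADME assay on WI-38 cells (Homo sapiens) for inhibition, read by CellTiter-Glo, with a stated time of 48 h, tested at 100 uM (on this read-out higher numbers stand for more inhibition at the one concentration tested (going by the name of the read-out) and lower numbers for less inhibition), compound 1 gives 1%, and in this assay compound 2 gives 4%. The step of a number 3 percentage points higher from compound 1 to compound 2 (within the scatter) comes with phenyl in place of methyl on a saturated chain carbon bound to an oxygen next to a carbonyl group, so the two compounds cannot be told apart on these numbers; both sit near the bottom of the scale. Compound 3 `COC(=O)/C=C\NC(=O)[C@H](O)C(C)(C)CO` has the same core with a third ester, and in this assay compound 3 gives "not determined" (no result reported).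

Compound 4 `CC(C)(CO)[C@@H](O)C(=O)N/C=C/C(=O)OCc1ccccc1` is the next step from compound 2. The change is the two compounds have the same atoms and bonds and differ only in configuration as drawn: 1 of 2 stereo elements differ; a double bond is drawn Z in compound 2 and E in compound 4. Within the data shown here, no measured step changes the drawn configuration of this double bond, so nothing measured bears on it directly; the only step available is the small one from compound 1 to compound 2. With both measured numbers near zero, a change in this assay of about no change at the digits printed from compound 2 to compound 4 (within the scatter) is expected, which is none beyond the scatter. Compound 4 is therefore estimated at 4%, within a range from -5% to 14%.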

Compound 4, a percentage reported as inhibition, at one concentration (the size of the read-out at that concentration, not a potency): 19%
Compound 4: middle estimate off by 15 percentage points, on the low side, outside the stated range (above it).
By their numbers in this assay, from the lowest: compounds 1 and 2 (each within the scatter of the next); then compound 4.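

Turning the double bond from Z to E gives a number 15 percentage points higher from compound 2 to compound 4 (beyond the scatter) in this assay. Among these compounds, the only earlier step, a change of ester, stayed within the scatter, so this is the first sign that the read-out responds to any change, and the response is modest. The shift can be tied to the geometry of the double bond alone because nothing else changes: the fact that compounds 2 and 4 differ only in the configuration as drawn

Only this one Z and E pair is shown, so it remains open whether the E form would bring a similar rise with the ester of compound 1 or compound 3. As far as these compounds go, it is also open how the number would move if a carboxylic acid took the place of the ester in the E form.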